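The source may hold more compounds than are shown below. What is called first, only, known or untested is meant among the compounds shown, and "the series" means these compounds.

In a functional assay on A-375 cells (Homo sapiens) for antiproliferative activity, read by MTT assay, with a stated time of 24 h (on this read-out higher numbers stand for weaker inhibition and lower numbers for stronger inhibition), compound 1 (`COc1cc(OC)c(-c2coc3cc(OCc4ccc(C#N)cc4)ccc3c2=O)cc1OC`) gives 1550 nM on the read-out, compound 2 (`COc1cc(OC)c(-c2coc3cc(OCc4ccccc4C#N)ccc3c2=O)cc1OC`) gives 990 nM and compound 3 (`COc1cc(OC)c(-c2coc3cc(OCc4ccc(Cl)cc4)ccc3c2=O)cc1OC`) gives 1020 nM in the same test. Compound 3 thus stands within the scatter of both other compounds, with a 1.0-fold higher number from compound 2 to compound 3 (0.01 log units; within the scatter) and a 1.5-fold lower number from compound 1 to compound 3 (0.18 log units; within the scatter) as the two steps that reach it. The next structure is compound 4 (`COc1cc(OC)c(-c2coc3cc(OCc4cccc(C(F)(F)F)c4)ccc3c2=O)cc1OC`), reached from compound 3 by 3-(trifluoromethyl)phenyl in place of 4-chlorophenyl on a saturated chain carbon bound to an oxygen on an aromatic ring as the difference, which is 3-(trifluoromethyl)phenyl in place of 4-chlorophenyl on a saturated chain carbon bound to an oxygen on an aromatic ring. The measured steps at this same place all stay within the scatter: a 1.6-fold lower number from compound 1 to compound 2 (0.19 log units; within the scatter) for 2-cyanophenyl in place of 4-cyanophenyl, and the two steps to compound 3 given above. Within the data shown here, no measured compound carries a trifluoromethyl group, which leaves the estimate resting on these three compounds alone. In this assay the expected result is a 1.1-fold higher number from compound 3 to compound 4 (0.03 log units; within the scatter) as the step, which means no expected change beyond the scatter. For compound 4 the estimated value is 1100 nM with an expected range from 500 nM to 2400 nM in this test.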

Compound 4, half-maximal inhibitory concentration: 1140 nM
For compound 4 the middle estimate is 1.0-fold (0.02 log units) below the measured one; measured number inside the range.
By their numbers in this assay, from the lowest: compounds 2, 3, 4 and 1 (each within the scatter of the next).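

In this assay the 3-(trifluoromethyl)phenyl group on the saturated chain carbon bound to an oxygen on an aromatic ring cannot be told apart from any of the three groups seen before: a 1.1-fold higher number from compound 3 to compound 4 (0.05 log units; within the scatter) against 4-chlorophenyl and a 1.2-fold higher number from compound 2 to compound 4 (0.06 log units; within the scatter) against 2-cyanophenyl and a 1.4-fold lower number from compound 1 to compound 4 (0.13 log units; within the scatter) against 4-cyanophenyl. The series now adds a trifluoromethyl substituent to the chloro and nitrile ones, and the entering group, with 10 heavy atoms against 7 for 4-chlorophenyl, still gives no step beyond the scatter among the four compounds at this place. Nothing on hand offers an explanation for this flat read-out.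

From the compounds shown here alone, all four compounds carry a substituted benzyl group at this place, so it remains open whether the number moves beyond the scatter with a group of another kind there, such as an amine, a carboxylic acid or a longer chain in place of the benzyl group. Every compound shown also carries the same core, and what a change in that core would do to the read-out stays open.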